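The source may report more compounds than this note shows. Statements on the series, on what has been measured and on what is new or still open speak of the compounds shown alone.

Measured so far:
Compound 1 `COc1cc(OC)c(C(=O)/C=C/c2ccc(Cl)cc2)c(OC)c1` gives 7500 nM
Compound 2 `COc1cc(OC)c(C(=O)/C=C/c2ccc(Br)cc2)c(OC)c1` gives 9500 nM
Compound 3 `COc1cc(OC)c(C(=O)/C=C/c2ccccc2SC)c(OC)c1` gives 9300 nM

All three numbers come from a functional assay on MCF7 cells (Homo sapiens) for cytotoxicity, with a stated time of 48 h (on this read-out lower numbers stand for stronger inhibition and higher numbers for weaker inhibition), and sit close together. Compound 2 stands apart from neither neighbour: the step of a 1.3-fold higher number from compound 1 to compound 2 (0.10 log units; within the scatter) and the step of a 1.0-fold lower number from compound 2 to compound 3 (0.01 log units; within the scatter) are both within the scatter, as is the step of a 1.2-fold higher number from compound 1 to compound 3 (0.09 log units; within the scatter) between the other two. Among the compounds with values here, nothing measured so far moves this assay beyond its scatter.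

Compound 4 `COc1cc(OC)c(C(=O)/C=C/c2ccc([N+](=O)[O-])cc2)c(OC)c1` is the next member. Compared with compound 2 the change is nitro in place of bromo on an aromatic carbon. Within the data shown here, the steps that bear on it are the halogen exchange at the same place, from compound 1 to compound 2, and the exchange of the whole aryl group, from compound 2 to compound 3; both left this assay flat. No measured step involves a nitro group, so its effect here is unknown, but the series gives no reason to expect a step beyond the scatter in either direction for this assay.

Compound 4 is therefore expected to give 9000 nM in this assay, within a range of 3500 nM to 20000 nM, the step of a 1.1-fold lower number from compound 2 to compound 4 (0.02 log units; within the scatter) being an estimate only.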

Compound 4, half-maximal inhibitory concentration: 5000 nM
Compound 4: the middle estimate sits 1.8-fold (0.26 log units) above what was measured; the measured number falls inside the stated range.
By their numbers in this assay, from the lowest: compounds 4, 1, 3 and 2 (each within the scatter of the next).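

In this assay, the aromatic carbon para to a large group now carries something other than a halogen: nitro, with 3 heavy atoms and 2 hydrogen-bond acceptors, in place of bromo, with 1 heavy atom and none. Even so, the step of a 1.9-fold lower number from compound 2 to compound 4 (0.28 log units; within the scatter) stays within the scatter, as does the step of a 1.5-fold lower number from compound 1 to compound 4 (0.18 log units; within the scatter), so this position has now taken bromo, chloro and nitro without a change beyond the scatter, which the halogen exchange alone could not show. No accompanying measurement offers an explanation for this reading at the position.

As far as these compounds go, whether an amine, a carboxylic acid or a group with a longer chain on this same carbon would also stay within the scatter remains open. Also open, from the compounds shown here alone, is whether the same flat reading holds for changes elsewhere on the shared core, or in any read-out other than this assay.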